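Benzyl on the Ring Nitrogen of a Substance-P Antagonist

The source may report more compounds than this note shows. Statements on the series, on what has been measured and on what is new or still open speak of the compounds shown alone.

Compound 1 `COc1ccccc1-c1[nH]c2ccc(C)cc2c1CCC(=O)N1CCN(c2ccccc2OC)CC1` gives 82 nM in an assay on CHO cells for displacement of a labelled ligand from Substance-P receptor (Homo sapiens); a higher number here means a weaker inhibitor, a lower number a stronger inhibitor. Compound 2 `COc1ccccc1N1CCN(C(=O)CCc2c(-c3ccc(Cl)cc3)[nH]c3ccc(C)cc23)CC1` gives 0.6 nM. Compound 3 `COc1ccccc1N1CCN(C(=O)CCc2c(-c3ccc(Cl)cc3)[nH]c3ccc(Cl)cc23)CC1` gives 0.89 nM.

Compound 3 stands second highest of the three numbers in this assay; its nearest neighbour is compound 2, and the two lie within the scatter of each other, while compound 1 is far from it, beyond the scatter. Compound 4 `COc1ccccc1N1CCN(C(=O)CCc2c(-c3ccc(Cl)cc3)n(Cc3ccccc3)c3ccc(Cl)cc23)CC1` differs from compound 3 in one place: benzyl in place of hydrogen on an aromatic nitrogen.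

Neither measured step touches this ring nitrogen. The step of a 140-fold lower number from compound 1 to compound 2 (2.14 log units; beyond the scatter) concerns the aryl group on an aromatic carbon, and the step of a 1.5-fold higher number from compound 2 to compound 3 (0.17 log units; within the scatter) concerns a substituent on another aromatic carbon. Nothing in the measured compounds shows what happens when the hydrogen on the ring nitrogen is replaced by a benzyl group, so the direction and size of the step cannot be read from the data.

Given that lack of guidance, compound 4 is expected to show a moderately higher number than compound 3, with a wide range, as expressed by the expected step of a 17-fold higher number from compound 3 to compound 4 (1.23 log units; beyond the scatter). The estimate for compound 4 in this assay is 15 nM, within a range from 1.5 nM to 150 nM.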

Compound 4, half-maximal inhibitory concentration: 96 nM
Estimate against measurement, compound 4: 6.4-fold (0.81 log units) below; measured number inside the range.
By their numbers in this assay, from the lowest: compounds 2 and 3 (each within the scatter of the next); then compounds 1 and 4 (each within the scatter of the next).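

In this assay, among these compounds, benzyl in place of hydrogen on the aromatic nitrogen gives a 110-fold higher number from compound 3 to compound 4 (2.03 log units; beyond the scatter), so this ring nitrogen, which no earlier step touched, proves to be a place where a single change weakens binding strongly. The shared core does not respond alike everywhere: chloro in place of methyl on an aromatic carbon gave only a 1.5-fold higher number from compound 2 to compound 3 (0.17 log units; within the scatter), whereas this substitution, with its seven added carbon atoms and its six-membered aromatic ring, moves the number far beyond the scatter. Nothing available here accounts for the size of this step.

The compounds shown leave open whether the loss follows from removing the hydrogen on the ring nitrogen or from the size of what replaces it, a question that a methyl or ethyl group at the same place would address. They also leave open whether a longer chain such as phenethyl, a benzyl ring carrying a substituent such as fluoro, or a chain ending in an amine or a carboxylic acid would fare any differently.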